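The source may report more compounds than this note shows. Statements on the series, on what has been measured and on what is new or still open speak of the compounds shown alone.

Compound 1 `ClCc1ccc(Cn2cnc3c(Cl)ncnc32)cc1` gives 32400 nM in a functional assay on HOP-62 cells (Homo sapiens) for cytotoxicity, read by sulforhodamine B assay, with a stated time of 48 h; a lower number here means that less compound is tolerated, a higher number that more compound is tolerated. Compound 3 `ClCc1ccc(Cn2cnc3c(Cl)nc(Cl)nc32)cc1`, which carries chloro in place of hydrogen on an aromatic carbon, gives 19500 nM in this assay, and the step of a 1.7-fold lower number from compound 1 to compound 3 (0.22 log units; within the scatter). Compound 2 `ClCc1cccc(Cn2cnc3ncnc(Cl)c32)c1` has the same atoms as compound 1 joined differently; how the two cores differ is not broken down here. In this assay compound 2 gives 7410 nM, the lowest of the three numbers. Among the compounds with values here, compound 4 `ClCc1cccc(Cn2cnc3nc(Cl)nc(Cl)c32)c1` is not yet measured; relative to compound 2 it carries chloro in place of hydrogen on an aromatic carbon, the same change as the one from compound 1 to compound 3, at a place described in the same words. The step from compound 2 to compound 4 in this assay is expected to be a 1.5-fold lower number from compound 2 to compound 4 (0.17 log units; within the scatter), resting on a 1.7-fold lower number from compound 1 to compound 3 (0.22 log units; within the scatter), which lies within the scatter. For compound 4 the estimate is 5000 nM, with a range from 2500 nM to 12000 nM.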

Compound 4, concentration lethal to 50% of the cells: 6020 nM
Compound 4: middle estimate off by 1.2-fold (0.08 log units), on the low side, within the range that was stated.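

In this assay, chloro in place of hydrogen on an aromatic carbon gives a 1.2-fold lower number from compound 2 to compound 4 (0.09 log units; within the scatter). Set beside the earlier step, the change reads the same on the two cores: the same change on two cores in this assay, a 1.7-fold lower number (0.22 log units; within the scatter) from compound 1 to compound 3 and a 1.2-fold lower number (0.09 log units; within the scatter) from compound 2 to compound 4, 1.3-fold (0.13 log units) apart, within the scatter of two such steps. This supports carrying the step between these two cores in this assay only; as each step lies within the scatter, neither shows that chloro changes the number on its core, and two pairs make no rule for the series.

Open, going by these compounds, is whether an amine or a methoxy group on this carbon between two ring nitrogen atoms would give a step beyond the scatter. Also open, on these data alone, is whether such a step would carry between the two cores.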